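Reversing a chloro-to-methoxyethoxy swap on the urea aryl

The compounds below may be only part of what the source reports. "The series", "measured", "known", "first", "only" and "open" are said of these compounds alone.

For the measured compounds named here, compound 2 `Cc1ccc(/C=C/C=N/NC(=O)CN2C(=O)N(c3ccc(Cl)cc3)C(N(O)C(=O)Nc3ccc(Cl)cc3)C2(C)C)o1` gives 6.8 h in an ADME assay on liver (Mus musculus) for metabolic stability, read by LC-MS, using microsomes, tested at 1 uM, in the presence of a further agent that is not named here (on this read-out higher numbers stand for a longer-lived compound and lower numbers for a shorter-lived compound), the lower of the two numbers measured so far. Going by the values given here, compound 1 `COCCOc1ccc(N2C(=O)N(CC(=O)N/N=C/C=C/c3ccc(C)o3)C(C)(C)C2N(O)C(=O)Nc2ccc(Cl)cc2)cc1` gives 14.4 h in this assay, and the only measured step, a 2.1-fold lower number from compound 1 to compound 2 (0.33 log units; beyond the scatter), is the one that links them. Compound 3 `COCCOc1ccc(NC(=O)N(O)C2N(c3ccc(Cl)cc3)C(=O)N(CC(=O)N/N=C/C=C/c3ccc(C)o3)C2(C)C)cc1` has not been measured; it differs from compound 2 by 2-methoxyethoxy in place of chloro on an aromatic carbon, on an aromatic carbon para to a large group. Among the compounds with values here, this is the same exchange as the measured step run in the opposite direction, though on a different aromatic ring of the shared core, so the sole bearing of that step is indirect. On that basis the expected change in this assay is a 1.8-fold higher number from compound 2 to compound 3 (0.25 log units; within the scatter), an increase of roughly the size seen before, with wide uncertainty because only a 2.1-fold lower number from compound 1 to compound 2 (0.33 log units; beyond the scatter) informs it. Compound 3 is therefore estimated at 12 h, with a range of 6 h to 25 h.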

Compound 3, half-life: 16.5 h
Estimate against measurement, compound 3: 1.4-fold (0.14 log units) below; measured number inside the range.
By their numbers in this assay, from the lowest: compound 2; then compounds 1 and 3 (each within the scatter of the next).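

On the aromatic carbon para to a large group in the (4-chlorophenyl)amino part of compound 2, 2-methoxyethoxy in place of chloro gives a 2.4-fold higher number from compound 2 to compound 3 (0.38 log units; beyond the scatter) in this assay and so shows that this ring also responds to the exchange. The earlier step, a 2.1-fold lower number from compound 1 to compound 2 (0.33 log units; beyond the scatter), had read the exchange only on the other aromatic ring, and the two steps now agree in direction, with the 2-methoxyethoxy compound carrying the higher number on each ring. No measurement at hand accounts for this shift in half-life.

The compounds shown leave open whether 2-methoxyethoxy on both aromatic rings would raise the number further. They also leave open how a shorter chain such as methoxy, or an amine such as morpholine, would read at this position.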